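A 6-methoxypyridin-3-yl group replaces 4-methoxyphenyl

The source may hold more compounds than are shown below. What is called first, only, known or untested is meant among the compounds shown, and "the series" means these compounds.

In a functional assay on HeLa cells (Homo sapiens) for antiproliferative activity, read by MTT assay, with a stated time of 72 h (on this read-out lower numbers stand for stronger inhibition and higher numbers for weaker inhibition), compound 1 `CC/C=C/C(=O)Nc1cccc(Oc2nc(Nc3ccc(OC)cc3)nc3c2CSCC3)c1` gives 27200 nM, compound 2 `CCC/C=C/C(=O)Nc1cccc(Oc2nc(Nc3ccc(OC)cc3)nc3c2CSCC3)c1` gives 12800 nM, and compound 3 `COc1ccc(Nc2nc3c(c(Oc4cccc(NC(=O)/C=C/C(C)C)c4)n2)CSCC3)cc1` gives 22900 nM. Compound 3 thus lies within the scatter of both others. Compound 4 `COc1ccc(Nc2nc3c(c(Oc4cccc(NC(=O)/C=C/C(C)C)c4)n2)CSCC3)cn1` differs from it in one place, (6-methoxypyridin-3-yl in place of 4-methoxyphenyl on a nitrogen on an aromatic ring), with 6-methoxypyridin-3-yl in place of 4-methoxyphenyl on a nitrogen on an aromatic ring. The measured steps all alter a chain elsewhere, and none tests this exchange. They offer only a sense of scale: a 2.1-fold lower number from compound 1 to compound 2 (0.33 log units; beyond the scatter), a 1.2-fold lower number from compound 1 to compound 3 (0.07 log units; within the scatter) and a 1.8-fold higher number from compound 2 to compound 3 (0.25 log units; within the scatter). Only the first exceeds the scatter, and modestly. The expected change is therefore none beyond the scatter, with an estimated 1.1-fold higher number from compound 3 to compound 4 (0.04 log units; within the scatter). Compound 4 is estimated at 25000 nM, within an expected range of 10000 nM to 60000 nM.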

Compound 4, half-maximal inhibitory concentration: 27800 nM
The estimate for compound 4 lay 1.1-fold (0.05 log units) below the measured number; the measured number falls inside the stated range.
By their numbers in this assay, from the lowest: compounds 2, 3, 1 and 4 (each within the scatter of the next, the first and the last beyond it).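

In this assay, among these compounds, placing 6-methoxypyridin-3-yl in place of 4-methoxyphenyl on the nitrogen gives a 1.2-fold higher number from compound 3 to compound 4 (0.08 log units; within the scatter), the first test at this position, where the earlier steps altered only the chain. Here a ring nitrogen and a second hydrogen-bond acceptor in the group leave the number within the scatter of compound 3. No supporting data bear on the reason for this result.

As far as these compounds go, whether a 4-aminophenyl, a 4-carboxyphenyl or a pyrimidine ring on this nitrogen would move the number beyond the scatter stays open. So does whether the same exchange would read alike with the chain of compound 2.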